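The source may report more compounds than this note shows. Statements on the series, on what has been measured and on what is new or still open speak of the compounds shown alone.

Compound 1 `CCCn1c(NC(=O)c2ccccn2)nc2cc(C(N)=O)cc(OC)c21`: > 100000 nM
Compound 2 `CCCn1c(NC(=O)c2ccnn2C)nc2cc(C(N)=O)cc(OC)c21`: > 100000 nM

In an assay for activation of interferon regulatory factor 3 (Homo sapiens), read by a luciferase reporter, with a stated time of 20 h (on this read-out lower numbers stand for an effect already at smaller amounts and higher numbers for an effect only at larger amounts of compound), compound 1 gives > 100000 nM, which is a limit of the assay rather than a measured number. Compound 2 gives > 100000 nM in this assay, again a limit. For the measured compounds named here, both measured values therefore sit at the same ceiling, as the limit of > 100000 nM in this assay, at which 2 of the 2 values shown sit, shows, and the only measured step, a step that the two limits leave unreadable from compound 1 to compound 2, cannot be read in size or direction.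

Compound 3 `CCCn1c(NC(=O)c2cncn2C)nc2cc(C(N)=O)cc(OC)c21` differs from compound 2 by 1-methyl-1H-imidazol-5-yl in place of 1-methyl-1H-pyrazol-5-yl on a carbonyl carbon. Going by the values given here, no measured step bears on this particular exchange; the one step that exists is unreadable, so the expectation rests only on where compound 2 stands, at the limit. The change from compound 2 to compound 3 is expected to give no step beyond the scatter, a step that the limit leaves unreadable from compound 2 to compound 3. Compound 3 is therefore estimated at 150000 nM, with a range from 30000 nM to 1000000 nM, and most likely a limit will again be reported.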

Compound 3, half-maximal effective concentration: > 100000 nM
Compound 3: only a limit was reported; the forecaster's own chance of this, stated with the estimate: 85%; the middle value is on the limit's open side.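

For the compounds shown here, no step among compound 1, compound 2 and compound 3 can be read, since all three stand at the same ceiling in this assay: the limit of > 100000 nM in this assay, at which 3 of the 3 values shown sit. The compounds shown leave open how these three groups on the carbonyl carbon truly compare, and what change would bring a value within the measurable range.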